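A few compounds are considered here, and "the series" means these few. Any claim that something is new, unique, unknown or untested is made for them only; others in the source may bear on it.

Measured so far in a functional assay on A549 cells (Homo sapiens) for antiproliferative activity, read by spectrophotometry, with a stated time of 2 days; on this read-out higher numbers stand for weaker inhibition of growth and lower numbers for stronger inhibition of growth:
- compound 1 `COc1ccc(Nc2ncc(C(F)(F)F)c(N3Cc4cccc(N(C)S(C)(=O)=O)c4C3)n2)cc1C(F)(F)F`: > 30000 nM, a limit
- compound 2 `CC(=O)N1CCN(c2ccc(Nc3ncc(C(F)(F)F)c(N4Cc5cccc(N(C)S(C)(=O)=O)c5C4)n3)cc2)CC1`: 1300 nM
- compound 3 `COc1ccc(C(F)(F)F)cc1Nc1ncc(C(F)(F)F)c(N2Cc3cccc(N(C)S(C)(=O)=O)c3C2)n1`: > 30000 nM, a limit

Within the data shown here, compound 2 gives the only actual number in the set, 1300 nM in this assay. The rest of the set stands at the limit of > 30000 nM in this assay, at which 2 of the 3 values shown sit.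

Next in the series is compound 4 `COc1cc(N2CCN(C(C)=O)CC2)ccc1Nc1ncc(C(F)(F)F)c(N2Cc3cccc(N(C)S(C)(=O)=O)c3C2)n1`, which differs from compound 2 by methoxy in place of hydrogen on an aromatic carbon. In words, this is methoxy in place of hydrogen on an aromatic carbon, ortho to a large group and meta to a 4-acetylpiperazin-1-yl group.

Among the measured compounds shown here, the one measured step that involves a methoxy group is a step that the two limits leave unreadable from compound 1 to compound 3. For the measured compounds named here, it has no readable size, and no measured step adds a methoxy group to a ring carrying the 4-acetylpiperazin-1-yl group. Going by the values given here, the only anchor is therefore compound 2 at 1300 nM. No step beyond the usual scatter is expected in this assay, in either direction, although the expectation is weakly supported and the range is kept wide.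

Compound 4 is estimated at 1200 nM, with an expected range of 300 nM to 5000 nM. The expected change is a 1.1-fold lower number from compound 2 to compound 4 (0.03 log units; within the scatter).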

Compound 4, concentration for 50% growth inhibition: 3300 nM
Beside the measured number, compound 4's estimate is 2.8-fold (0.44 log units) below it, within the range that was stated.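

In this assay, methoxy in place of hydrogen on an aromatic carbon, ortho to a large group and meta to a 4-acetylpiperazin-1-yl group, gives a 2.5-fold higher number from compound 2 to compound 4 (0.40 log units; beyond the scatter), a modest weakening of growth inhibition. Among these compounds, this is the only methoxy change with a readable size, as the step between compound 1 and compound 3 cannot be read. It also shows that this position accepts a methoxy group with the read-out still a measured number and not a limit, so the ring carrying the 4-acetylpiperazin-1-yl group has some room for change at this carbon. Nothing measured here bears on the cause of this step.

As far as these compounds go, whether a hydroxy group, a fluorine or a longer ethoxy chain on the same aromatic carbon would give a step of similar size stays open, so the step cannot yet be assigned to methoxy itself as opposed to any group at this position. Also open, from the compounds shown here alone, is whether the methoxy step keeps its size when the 4-acetylpiperazin-1-yl group gives way to a piperazine with a free amine.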